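A Step from 4-Chlorophenyl to Anilino in Growth Inhibition

The source may hold more compounds than are shown below. What is called first, only, known or untested is meant among the compounds shown, and "the series" means these compounds.

Three compounds form the starting record in a functional assay on OCI-Ly3 cells (Homo sapiens) for inhibition, read by CellTiter-Glo, with stated times of 48 h and 96 h (on this read-out higher numbers stand for weaker inhibition of growth and lower numbers for stronger inhibition of growth), and only one of them yields a number. Compound 1 `CCC(=O)[C@H](CCCNC(=N)N)NC(=O)[C@@H]1CCCN1C(=O)[C@@H](NC(=O)[C@H](CC(C)C)NC(=O)OCc1ccccc1)C(C)C` gives > 20000 nM in this assay, an entry that is a limit of the assay and not a number. For compound 2 `CC(C)[C@H](NC(=O)OCc1ccccc1)C(=O)N1CCC[C@H]1C(=O)N(C)[C@@H](CCCNC(=N)N)C(=O)CF`, the entry in this assay reads "not determined" (no result reported). Among the compounds with values here, compound 3 `CC(C)[C@H](NC(=O)c1ccc(Cl)cc1)C(=O)N1CCC[C@H]1C(=O)N[C@@H](CCCNC(=N)N)C(=O)CF` gives 1240 nM in this assay, and this is the only number available, so it serves as the single reference point for what follows.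

Compound 4 `CC(C)[C@H](NC(=O)Nc1ccccc1)C(=O)N1CCC[C@H]1C(=O)N[C@@H](CCCNC(=N)N)C(=O)CF` shares the rest of its structure with compound 3 and differs at one place: anilino in place of 4-chlorophenyl on a carbonyl carbon. Within the data shown here, no measured pair of compounds differs in one place, so the data offer no direct gauge for this exchange. The expectation therefore stays anchored on compound 3 at 1240 nM, with a slight lean towards weaker inhibition of growth but no shift beyond the usual scatter. The expected change is a 1.5-fold higher number from compound 3 to compound 4 (0.16 log units; within the scatter). In this assay, compound 4 is estimated at 1800 nM, with an expected range from 500 nM to 7000 nM.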

Compound 4, concentration for 50% growth inhibition: 1520 nM
The estimate for compound 4 lay 1.2-fold (0.07 log units) above the measured number; the range from low to high includes it.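

In this assay, within the data shown here, the first readable step is a 1.2-fold higher number from compound 3 to compound 4 (0.09 log units; within the scatter), with anilino in place of 4-chlorophenyl on a carbonyl carbon. This one pair shows that the position accepts the exchange of the chlorine-bearing group for anilino, which brings 1 hydrogen-bond donor, without a difference that can be told from the scatter, and both groups carry one six-membered aromatic ring of carbon only. The values shown give no cause for this result, and none of the evidence at hand bears on it.

Still open, going by these compounds, is how an unsubstituted phenyl, a 4-chloroanilino group, or a saturated amine such as piperidine on the same carbonyl carbon would compare with compound 3 and compound 4, so this pair cannot separate the loss of the chlorine from the gain of the amino nitrogen. Compound 1 gives > 20000 nM, which is a limit of the assay and not a number, and it differs from compound 3 in more than one place, so it offers no comparison.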